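The compounds below may be only part of what the source reports. "The series", "measured", "known", "first", "only" and "open" are said of these compounds alone.

Compound 3 `N/C(=N\NC(=S)N1CCOCC1)c1ccc(F)cn1` is one of three related compounds measured in a functional assay on A-431 cells (Homo sapiens) for cytotoxicity, read by MTT assay, with a stated time of 72 h, tested at 100 uM (on this read-out higher numbers stand for more inhibition of growth at the one concentration tested and lower numbers for less inhibition of growth), and compound 3 gives 85.6%. Compound 1 `Cc1ccnc(/C(N)=N/NC(=S)N2CCCC2)c1` gives 86.9% and compound 2 `N/C(=N\NC(=S)N1CCSCC1)c1ccccn1` gives 80.8%. All three numbers lie within the usual scatter of one another, so none of them can be called higher or lower than the others with any confidence. Compound 4 `N/C(=N\NC(=S)N1CCOCC1)c1ccccn1` differs from compound 3 in a single place: hydrogen in place of fluoro on an aromatic carbon. Going by the values given here, no pair of measured compounds shows what this change does on its own. All three measured numbers sit close together. The step expected a number 1.6 percentage points lower from compound 3 to compound 4 (within the scatter) is one that stays within the scatter, in no particular direction. Compound 4 is therefore estimated at 84%, with a range from 72% to 94%.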

Compound 4, percent growth inhibition at one concentration: 84.6%
Estimate against measurement, compound 4: 0.6 percentage points below, within the range that was stated.
By their numbers in this assay, from the lowest: compounds 2, 4, 3 and 1 (each within the scatter of the next).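

In this assay hydrogen in place of fluoro on this aromatic carbon, para to a large group, gives a number 1 percentage points lower from compound 3 to compound 4 (within the scatter) and so the fluoro makes no clear difference here. Morpholin-4-yl in place of thiomorpholin-4-yl on the thiocarbonyl carbon gives a number 3.8 percentage points higher from compound 2 to compound 4 (within the scatter) and so this ring swap also makes no clear difference. No measurement is available to explain either result.

Going by these compounds, whether a carboxylic acid or an amine at this aromatic carbon would shift the number remains open. So does whether fluoro and hydrogen would differ at lower concentrations.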